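Piperazine-aryl replacement in the shared core: compound 4

The compounds below may be only part of what the source reports. "The series", "measured", "known", "first", "only" and "open" are said of these compounds alone.

Measured so far in a functional assay on cells (T-cell, Homo sapiens) for inhibition; on this read-out higher numbers stand for weaker inhibition and lower numbers for stronger inhibition:
- compound 1 `COc1ccc(-c2cnc3nc(N)nc(N4CCN(c5cc(Cl)cc(Cl)c5)CC4)c3n2)cc1OC` gives 3400 nM
- compound 2 `COc1ccc(-c2cnc3nc(N)nc(OC(C)C)c3n2)cc1OC` gives 400 nM
- compound 3 `COc1ccc(-c2cnc3nc(N)nc(N4CCN(C(=O)Nc5ccc(C#N)cc5)CC4)c3n2)cc1OC` gives 74 nM

Compound 3 stands lowest of the three numbers in this assay; compound 2 is nearest and compound 1 furthest, both beyond the scatter. The next compound, compound 4 `COc1ccc(-c2cnc3nc(N)nc(N4CCN(c5ccccc5)CC4)c3n2)cc1OC`, differs from compound 3 in one place: phenyl in place of (4-cyanophenyl)carbamoyl on an amine nitrogen in a ring.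

Within the data shown here, one measured step bears on this. It runs in the opposite sense, an aryl on the same ring nitrogen giving way to the carbamoyl group: a 46-fold lower number from compound 1 to compound 3 (1.66 log units; beyond the scatter). Compound 4 carries a plain aryl on that nitrogen, as compound 1 does, so the step from compound 3 to compound 4 is expected to undo much of that gain and to give a higher number, beyond the scatter. Because compound 1 sits at 3400 nM with a substituted aryl in that place, compound 4 is expected to land between compound 1 and compound 3, nearer compound 1: a 20-fold higher number from compound 3 to compound 4 (1.31 log units; beyond the scatter), estimated at 1500 nM (range 400 nM to 5000 nM).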

Compound 4, half-maximal inhibitory concentration: 400 nM
Beside the measured number, compound 4's estimate is 3.8-fold (0.57 log units) above it; measured number inside the range.
By their numbers in this assay, from the lowest: compound 3; then compounds 2 and 4 (each within the scatter of the next); then compound 1.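

On the amine nitrogen in the ring, the aryl group itself matters: in this assay, phenyl in place of 3,5-dichlorophenyl gives an 8.5-fold lower number from compound 1 to compound 4 (0.93 log units; beyond the scatter) and so shows that this position responds to a change of aryl substitution alone. Part of the earlier step of a 46-fold lower number from compound 1 to compound 3 (1.66 log units; beyond the scatter) therefore reflects the 3,5-dichlorophenyl group in compound 1 and not only the arrival of the carbamoyl group. The comparison with the unsubstituted aryl still favours the urea-bearing compound, as a 5.4-fold higher number from compound 3 to compound 4 (0.73 log units; beyond the scatter) is beyond the scatter, but no measurement at hand explains either new step.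

Still open, on these data alone, is how much of compound 3's standing rests on the nitrile and how much on the carbamoyl link. An unsubstituted phenylcarbamoyl group, or a single chlorine on the phenyl, would separate these contributions.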